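N-Methylation of a Piperidine Amine in Two Related Cores

A few compounds are considered here, and "the series" means these few. Any claim that something is new, unique, unknown or untested is made for them only; others in the source may bear on it.

Measured so far:
Compound 1, `O=S(=O)(c1cc(Cl)cc(Cl)c1)c1cn(C2CCCNC2)c2ncccc12`, gives 297 nM in a functional assay on HeLa cells for agonist activity at 5-hydroxytryptamine receptor 6 (Homo sapiens), read by cAMP accumulation and immunoassay; a lower number here means that less compound is needed, a higher number that more compound is needed for the effect.
Compound 2, `CN1CCCC(n2cc(S(=O)(=O)c3cc(Cl)cc(Cl)c3)c3cccnc32)C1`, gives 38.7 nM in this assay.
Compound 3, `O=S(=O)(C1=C(Cl)NC2SC=CN12)c1cn(C2CCCNC2)c2ncccc12`, gives 66 nM in this assay.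

Compounds 1 and 2 differ in one place, (methyl in place of hydrogen on an amine nitrogen in a ring), and that step gave a 7.7-fold lower number from compound 1 to compound 2 (0.89 log units; beyond the scatter). Compound 3 differs from compound 1 in its core, (a group of 9 heavy atoms (5 carbon, 2 nitrogen, 1 sulfur, 1 chlorine; 2 five-membered non-aromatic rings with 2 hetero atoms each) in place of a group of 8 heavy atoms (6 carbon, 2 chlorine; one six-membered aromatic ring of carbon only), on a sulfonyl sulfur), and that step gave a 4.5-fold lower number from compound 1 to compound 3 (0.65 log units; beyond the scatter). Compound 4, `CN1CCCC(n2cc(S(=O)(=O)C3=C(Cl)NC4SC=CN34)c3cccnc32)C1`, is not yet measured; it differs from compound 3 in the same way, (methyl in place of hydrogen on an amine nitrogen in a ring), at a place described in identical words, so the change is the same one. Within the data shown here, because the earlier step was a 7.7-fold lower number from compound 1 to compound 2 (0.89 log units; beyond the scatter), a step of similar size is expected here, a 6.6-fold lower number from compound 3 to compound 4 (0.82 log units; beyond the scatter), though only one example supports it. Compound 4 is therefore estimated at 10 nM in this assay, between 3 nM and 30 nM.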

Compound 4, half-maximal effective concentration: 25 nM
Estimate against measurement, compound 4: 2.5-fold (0.40 log units) below; measured number inside the range.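

The methyl on the ring nitrogen, the change from piperidin-3-yl to 1-methylpiperidin-3-yl, still counts on the second core, with a 2.6-fold lower number from compound 3 to compound 4 (0.42 log units; beyond the scatter) in this assay, so the direction carries over but the size does not: the same change on two cores in this assay, a 7.7-fold lower number (0.89 log units; beyond the scatter) from compound 1 to compound 2 and a 2.6-fold lower number (0.42 log units; beyond the scatter) from compound 3 to compound 4, 2.9-fold (0.46 log units) apart, beyond the scatter of two such steps. Replacing the group on the sulfonyl sulfur leaves only a 1.5-fold lower number from compound 2 to compound 4 (0.19 log units; within the scatter) once the methyl is present, against a clear step without it: the same change on two cores in this assay, a 4.5-fold lower number (0.65 log units; beyond the scatter) from compound 1 to compound 3 and a 1.5-fold lower number (0.19 log units; within the scatter) from compound 2 to compound 4, 2.9-fold (0.46 log units) apart, beyond the scatter of two such steps. These two pairs do not show why the steps differ, or what size either change would have on a third core.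

Still open, from the compounds shown here alone, is how an ethyl or a longer chain on that ring nitrogen would compare with methyl. Also open, going by these compounds, is whether a pyrrolidine ring in place of the piperidine would keep these trends.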